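Working notes: cytotoxicity across three measured analogues

This account rests on a few compounds, and the source may have more. Where it says the series, first, only, none or still open, it means among the compounds named here.

Measured compounds in an ADME assay on BaF3 cells (Mus musculus) for cytotoxicity; on this read-out higher numbers stand for an effect only at larger amounts of compound and lower numbers for an effect already at smaller amounts:
- compound 1 `Nc1cccc(-c2cc(Nc3ccc(OC(F)(F)F)cc3)ncn2)c1`: > 10000 nM
- compound 2 `NS(=O)(=O)c1ccc(-c2cc(Nc3ccc(OC(F)(F)F)cc3)ncn2)cc1`: > 10000 nM
- compound 3 `FC(F)(F)Oc1ccc(Nc2cc(-n3ccnc3)ncn2)cc1`: > 10000 nM

Each of these three values is a limit of the assay and not a number. Compound 1 gives > 10000 nM in this assay, a limit. Compound 2 gives > 10000 nM in this assay, a limit. Compound 3 gives > 10000 nM in this assay, again a limit. Compound 3 therefore stands only at a limit, and the two other values shown are limits as well (the limit of > 10000 nM in this assay, at which 3 of the 3 values shown sit).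

Among the compounds with values here, the one measured step bearing on the present change, a step that the two limits leave unreadable from compound 1 to compound 3, is left unreadable by the two limits, so its size cannot be read.

The change to compound 4 `NC(=O)c1ccc(-c2cc(Nc3ccc(OC(F)(F)F)cc3)ncn2)cc1` is 4-carbamoylphenyl in place of 1H-imidazol-1-yl on an aromatic carbon. No measured step gives a readable size for such an exchange, and all three shown values sit at the same limit.

Compound 4 is therefore expected to remain at that limit, the estimate being 15000 nM with a range from 8000 nM to 40000 nM. The step from compound 3 to compound 4 is expected to be a step that the limit leaves unreadable from compound 3 to compound 4, that is, nothing beyond the scatter.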

Compound 4, half-maximal effective concentration: > 10000 nM
Compound 4 ended at the assay's limit; the forecaster's own chance of this, stated with the estimate: 85%; the middle value lies beyond the limit too.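

The steps from compound 1, compound 2 and compound 3 to compound 4 cannot be read, as each joins two limits: the limit of > 10000 nM in this assay, at which 4 of the 4 values shown sit. The compounds shown leave open whether any of these exchanges changes the result in this assay.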